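The source may hold more compounds than are shown below. What is called first, only, known or untested is meant among the compounds shown, and "the series" means these compounds.

Measured so far:
- compound 1, `COc1ccc(C2=C(c3cccs3)C(=O)N3CCCC3C2)cc1`: 5000 nM
- compound 2, `CSc1ccc(C2=C(c3ccncc3)C(=O)N3CCCC3C2)cc1`: 6000 nM

Both numbers come from a functional assay on HCT-116 cells (Homo sapiens) for cytotoxicity; a higher number here means a weaker inhibitor, a lower number a stronger inhibitor. Within the data shown here, of the two, that of compound 2 is the higher, but its only neighbour is compound 1 and the gap between them lies within the scatter, so the two compounds cannot be told apart on these data. Compound 3, `CSc1ccc(C2=C(c3cccs3)C(=O)N3CCCC3C2)cc1`, is still to be measured in this assay. It differs from compound 2 in one place: thiophen-2-yl in place of pyridin-4-yl on a double-bonded ring carbon. Among the measured compounds shown here, no step between two measured compounds shows this exchange, so its size cannot be read from the series. Compound 1 already carries thiophen-2-yl in the same place and in this assay compound 1 gives 5000 nM, close to the number of compound 2. The expectation is therefore no step beyond the scatter in this assay. For compound 3 the estimate is 5500 nM, with a range from 2500 nM to 12000 nM. The implied step a 1.1-fold lower number from compound 2 to compound 3 (0.04 log units; within the scatter) is expected to stay within the scatter.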

Compound 3, half-maximal inhibitory concentration: 270 nM
Compound 3: the middle estimate sits 20-fold (1.31 log units) above what was measured; measured number outside the range, below it.
By their numbers in this assay, from the lowest: compound 3; then compounds 1 and 2 (each within the scatter of the next).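

In this assay, thiophen-2-yl in place of pyridin-4-yl on the double-bonded ring carbon gives a 22-fold lower number from compound 2 to compound 3 (1.35 log units; beyond the scatter), so the group at this position can strongly change the number when the ring atom next to it bears 4-(methylsulfanyl)phenyl. Thiophen-2-yl alone does not give the low number: with it held in place, methylsulfanyl in place of methoxy on an aromatic carbon gives a 19-fold lower number from compound 1 to compound 3 (1.27 log units; beyond the scatter). Among these compounds, only compound 3 carries both groups, and only compound 3 stands apart.

Nothing on hand explains either step.
Still open, on these data alone, is whether another ring at the double-bonded carbon, such as phenyl or furan-2-yl, or a longer chain in place of the methyl on sulfur, would keep the number of compound 3.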